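A Methyl Group on the Ring Oxygen and Cell Toxicity

This account rests on a few compounds, and the source may have more. Where it says the series, first, only, none or still open, it means among the compounds named here.

Of the compounds shown here, three have been tested in an ADME assay on HEK293 cells (Homo sapiens) for cytotoxicity, read by reporter gene assay and resazurin assay, with a stated time of 48 h; on this read-out higher numbers stand for lower toxicity in this test and lower numbers for higher toxicity in this test. Compound 1 `COc1c(Br)cc(Br)cc1C(=O)Nc1ccccc1` reaches the ceiling of the test: in this assay compound 1 gives only a limit, > 100000 nM. Compound 2 `O=C(Nc1ccccc1)c1cc(Br)cc(Br)c1O` carries a hydrogen where compound 1 carries a methyl, and in this assay compound 2 gives 34000 nM. The change between them is methyl in place of hydrogen on an oxygen on an aromatic ring, and it brought an at least 2.9-fold higher number from compound 2 to compound 1 (0.46 log units; beyond the scatter); the size of that step is known only as a lower bound because of the limit of > 100000 nM in this assay, at which 1 of the 3 values shown sits. Compound 3 `O=C(Nc1ccc(Sc2nc3ccccc3s2)cc1)c1cc(Br)cc(Br)c1O` has a larger core; how its core differs from the core of compound 2 is not broken down here. In this assay compound 3 gives 66000 nM, a number within the scatter of the number for compound 2. Compound 4 `COc1c(Br)cc(Br)cc1C(=O)Nc1ccc(Sc2nc3ccccc3s2)cc1` is not yet measured. It differs from compound 3 by methyl in place of hydrogen on an oxygen on an aromatic ring, the same change as that from compound 2 to compound 1, at a place described in the same words. Within the data shown here, that earlier step, an at least 2.9-fold higher number from compound 2 to compound 1 (0.46 log units; beyond the scatter), is the only guide. The expected step in this assay is a 2.3-fold higher number from compound 3 to compound 4 (0.36 log units; beyond the scatter). Compound 4 is therefore expected to give about 150000 nM, within an estimated range from 60000 nM to 400000 nM, and the assay may well report only a limit.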

Compound 4, half-maximal cytotoxic concentration: > 100000 nM
Compound 4 was reported as a limit; the forecaster's own chance of this, stated with the estimate: 60%; the middle value does not contradict the limit.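

In this assay, compound 4 gives > 100000 nM, which is a limit of the assay and not a true number. Changing hydroxy to methoxy on the larger core gives an at least 1.5-fold higher number from compound 3 to compound 4 (0.18 log units; that floor lies within the scatter), so the number rises on both cores, but this floor alone does not clear the usual scatter, and the real step could be larger. Whether the change has the same size on both cores cannot be said, because each step is known only as a lower bound: the same change on two cores in this assay, an at least 2.9-fold higher number (0.46 log units; beyond the scatter) from compound 2 to compound 1 and an at least 1.5-fold higher number (0.18 log units; that floor lies within the scatter) from compound 3 to compound 4; the limit leaves it open whether they differ

The compounds shown leave open how a longer chain on this oxygen, such as ethoxy in place of methoxy, or an amine in place of the hydroxy, would read in this assay. Among these compounds, they also cover only two cores, so it remains unknown whether the change from hydroxy to methoxy would behave in the same way on a third core.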